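Swapping a Trifluoromethyl for a Methyl on the Ether Oxygen

This account rests on a few compounds, and the source may have more. Where it says the series, first, only, none or still open, it means among the compounds named here.

Of the compounds shown here, three sharing one core have been tested. In a functional assay on MCF7 cells (Homo sapiens) for inhibition, read by sulforhodamine B assay, with a stated time of 72 h (a lower number here means a stronger inhibitor, a higher number a weaker inhibitor), compound 1 `CC(c1ccc(-c2ccccc2)c(F)c1)c1nnc2n1N=C(c1ccc(OC(F)(F)F)cc1)CS2` gives 4800 nM, compound 2 `COc1ccc(C2=Nn3c(nnc3C(C)c3ccc4cc(OC)ccc4c3)SC2)cc1` gives 6600 nM, and compound 3 `CC(C)Cc1ccc(C(C)c2nnc3n2N=C(c2ccc(Br)cc2)CS3)cc1` gives 9400 nM. Compound 1 has the lowest of the three numbers, yet both other numbers sit within the scatter of it, so no order among them can be claimed. Compound 4 `COc1ccc(C2=Nn3c(nnc3C(C)c3ccc(-c4ccccc4)c(F)c3)SC2)cc1` is not yet measured; it differs from compound 1 in one place: methyl in place of trifluoromethyl on an oxygen on an aromatic ring. Within the data shown here, no measured pair shows this change by itself, so nothing here points to a shift beyond the scatter in either direction. For compound 4 the expected step of a 1.1-fold higher number from compound 1 to compound 4 (0.06 log units; within the scatter) is therefore small, and the estimate is 5500 nM, with a range from 2000 nM to 15000 nM.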

Compound 4, half-maximal inhibitory concentration: 2600 nM
Compound 4: middle estimate off by 2.1-fold (0.33 log units), on the high side; the range from low to high includes it.
By their numbers in this assay, from the lowest: compounds 4, 1, 2 and 3 (each within the scatter of the next, the first and the last beyond it).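

Changing trifluoromethoxy to methoxy on the aromatic ring gives a 1.8-fold lower number from compound 1 to compound 4 (0.27 log units; within the scatter) in this assay. Among these compounds, this is the first direct view of this change by itself, and it shows no shift that can be told apart from the scatter of repeated measurements. Nothing measured here offers an explanation for this result. The compounds shown leave open whether a longer chain on this oxygen, such as propyl, would shift the number beyond the scatter. An amine in place of the whole trifluoromethoxy group also remains an open case.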